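This account rests on a few compounds, and the source may have more. Where it says the series, first, only, none or still open, it means among the compounds named here.

Measured so far:
compound 1, `CC(=O)Nc1ccc(CNc2cc(Br)cc3[nH]ncc23)cc1`: 48%
compound 2, `Nc1ccc(CNc2cc(Br)cc3[nH]ncc23)cc1`: 3%

Going by the values given here, in an assay for inhibition of Indoleamine 2,3-dioxygenase 1 (Homo sapiens), with a stated time of 1 h, tested at 10 uM (a higher number here means more inhibition at the concentration tested (going by the name of the read-out), a lower number less inhibition), compound 1 gives 48%, whereas compound 2 gives 3%, the lowest of the two numbers; its only neighbour, compound 1, stands higher by more than the scatter. Among the compounds with values here, the one measured step, a number 45 percentage points lower from compound 1 to compound 2 (beyond the scatter), shows that the free amino on the aromatic ring goes with much less inhibition than the acetylated nitrogen.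

Compound 3, `N#Cc1ccc(CNc2cc(Br)cc3[nH]ncc23)cc1`, has not been measured. It differs from compound 2 in one place: cyano in place of amino on an aromatic carbon. The new group sits on an aromatic carbon of a six-membered aromatic ring of carbon only, para to a large group. Within the data shown here, the only measured step that bears on this change is a number 45 percentage points lower from compound 1 to compound 2 (beyond the scatter), which was large. Among the measured compounds shown here, because compound 2 gives 3% with the free amino, while compound 1 gives 48% with that nitrogen altered, changing away from the free amino is expected to raise inhibition, though a cyano has no measured precedent here, so the expected step of a number 19 percentage points higher from compound 2 to compound 3 (beyond the scatter) is moderate and uncertain. Compound 3 is estimated at 22%, with a range from 0% to 50%.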

Compound 3, a percentage reported as inhibition, at one concentration (the size of the read-out at that concentration, not a potency): 70%
Compound 3: the middle estimate sits 48 percentage points below what was measured; measured number above the stated range.
By their numbers in this assay, from the lowest: compound 2; then compound 1; then compound 3.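

In this assay, the step of a number 67 percentage points higher from compound 2 to compound 3 (beyond the scatter) shows that the low number of compound 2 is not a general feature of substitution at this ring position, since a cyano on the same aromatic carbon gives the highest number of the three compounds. Going by these compounds alone, the step of a number 22 percentage points higher from compound 1 to compound 3 (beyond the scatter) adds something the first pair could not show: acetylating the amino nitrogen is not the only change that restores inhibition, and a group with no nitrogen bonded directly to the ring goes beyond the acetamido compound. Nothing available explains why the cyano compound stands highest, so these numbers describe what happens without showing the reason.

Still open, going by these compounds, is whether the rise is particular to cyano or extends to other groups on this carbon, such as a carboxylic acid, a methyl ester, a trifluoromethyl or a simple chlorine atom. Also open, on these data alone, is how these three compounds compare in potency, as each number comes from a single tested concentration and a full concentration series would be needed to show that.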